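A few compounds are considered here, and "the series" means these few. Any claim that something is new, unique, unknown or untested is made for them only; others in the source may bear on it.

In an ADME assay on MT4 cells (Homo sapiens) for cytotoxicity, read by XTT assay, with a stated time of 3 days (a lower number here means that less compound is tolerated, a higher number that more compound is tolerated), compound 1 (`CC(C)c1c(OC2CCCCC2C)cc(Cc2ccc(Cl)cc2)[nH]c1=O`) gives 84000 nM. Compound 2 (`CC1CCCCC1Oc1cc(CCc2ccccc2)[nH]c(=O)c1I`) gives > 300000 nM, which is a limit of the assay and not a number. Compound 3 (`CC1CCCCC1Oc1cc(CCc2ccccc2)[nH]c(=O)c1Br`) differs from compound 2 in one place: bromo in place of iodo on an aromatic carbon, with bromo in place of iodo on an aromatic carbon. Within the data shown here, no measured pair of compounds shows what this exchange does, so no step beyond the usual scatter is expected in this assay, and neither direction is favoured. Compound 3 is estimated at 300000 nM, with an expected range from 130000 nM to 600000 nM.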

Compound 3, half-maximal cytotoxic concentration: 100000 nM
For compound 3 the middle estimate is 3.0-fold (0.48 log units) above the measured one, outside the stated range (below it).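

In this assay, the aromatic carbon para to the phenethyl group proves sensitive to which halogen it carries: bromo in place of iodo gives an at least 3.0-fold lower number from compound 2 to compound 3 (0.47 log units; beyond the scatter). With everything else unchanged, this single exchange leaves compound 3 less tolerated than compound 2. Compound 2 is recorded only as a limit, so the step has a minimum size but no exact one: the limit of > 300000 nM in this assay, at which 1 of the 3 values shown sits.

On these data alone, how chloro, methyl or an amine at this position would compare remains open. So does whether the bromo and iodo exchange would have the same effect with a different group in place of the phenethyl group.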